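A few compounds are considered here, and "the series" means these few. Any claim that something is new, unique, unknown or untested is made for them only; others in the source may bear on it.

Measured compounds:
compound 1, `O=C(O)Cc1sc(C(c2ccccc2)c2ccc(Cl)cc2)nc1-c1ccc(Cl)cc1`: 75 nM
compound 2, `O=C(O)Cc1sc(C(c2ccccc2)c2ccccc2)nc1-c1ccccc1`: 370 nM
compound 3, `O=C(O)Cc1sc(C(c2ccccc2)c2ccccc2)nc1-c1ccc(F)cc1`: 77 nM

In an in vitro functional assay on HEK285-7 cells for antagonist activity at prostaglandin D2 receptor 2 (Homo sapiens), read by BRET and beta-arrestin recruitment (a higher number here means a weaker inhibitor, a lower number a stronger inhibitor), compound 3 gives 77 nM and stands second highest of the three numbers. Its nearest neighbour is compound 1, which in this assay gives 75 nM, a value within the scatter of compound 3. Furthest away is compound 2, which gives 370 nM, and the single-point change from it is a 4.8-fold lower number from compound 2 to compound 3 (0.68 log units; beyond the scatter).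

Compound 4, `O=C(O)Cc1sc(C(c2ccccc2)c2ccc(Cl)cc2)nc1-c1ccc(F)cc1`, has not yet been measured. It differs from compound 3 by chloro in place of hydrogen on an aromatic carbon. Within the data shown here, no measured step shows this exact change; the one single-point step in the set concerns the fluoro on the other aryl ring, not a chloro on this one. Compound 1 does carry a chloro on the same ring as compound 4 would, though it also carries chloro rather than fluoro on the other ring, and its value sits within the scatter of compound 3. On that basis the expected step of a 1.3-fold lower number from compound 3 to compound 4 (0.11 log units; within the scatter) is small, not beyond the scatter. Compound 4 is therefore expected to give about 60 nM in this assay, with a range from 20 nM to 180 nM.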

Compound 4, half-maximal inhibitory concentration: 79 nM
Estimate against measurement, compound 4: 1.3-fold (0.12 log units) below; the range from low to high includes it.
By their numbers in this assay, from the lowest: compounds 1, 3 and 4 (each within the scatter of the next); then compound 2.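

In this assay, chloro in place of hydrogen on the phenyl ring, para to a large group, gives a 1.0-fold higher number from compound 3 to compound 4 (0.01 log units; within the scatter), so this position carries a 4-chlorophenyl with no difference that can be told from the scatter. The earlier compounds shown here showed a single-point effect only for fluoro on the other aryl ring, in a 4.8-fold lower number from compound 2 to compound 3 (0.68 log units; beyond the scatter), which lies beyond the scatter. With the 4-chlorophenyl in place, the halogen on that other ring can also be exchanged, since fluoro in place of chloro gives a 1.1-fold higher number from compound 1 to compound 4 (0.02 log units; within the scatter), likewise within the scatter.

The compounds shown leave open whether a methoxy, an amine or a longer chain would be accepted at this position as chloro is, and whether chloro here would give the same result with hydrogen on the other ring. Nothing available explains why these values fall as they do.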